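Removing the Chloro Group from Compound 1

The source may report more compounds than this note shows. Statements on the series, on what has been measured and on what is new or still open speak of the compounds shown alone.

Measured so far:
compound 1, `N=C(N)c1ccc(-c2ccc(-c3ccc(Cl)cc3)o2)o1`: 97.3%
compound 2, `COc1cccc(-c2ccc(-c3ccc(C(=N)N)s3)s2)c1`: 79%

In an ADME assay on cells (Erythrocyte, Homo sapiens) for activation, read by hemolysis, with a stated time of 30 min, tested at 10 mM (on this read-out lower numbers stand for a weaker effect and higher numbers for a stronger effect at the one concentration tested), compound 1 gives 97.3%, the highest of the two numbers; compound 2 gives 79%, a gap beyond the usual scatter. Compound 3, `N=C(N)c1ccc(-c2ccc(-c3ccccc3)o2)o1`, has not yet been measured in this assay. It differs from compound 1 by hydrogen in place of chloro on an aromatic carbon. Within the data shown here, no step between measured compounds matches this change, so the expected step is uncertain: the change is small and compound 1 already lies near the top of the range, so a modest drop, possibly within the scatter, is expected. Compound 3 is therefore estimated at 88% in this assay, within 55% to 100%, a step of a number 9.3 percentage points lower from compound 1 to compound 3 (within the scatter).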

Compound 3, a percentage reported as activity, at one concentration (the size of the read-out at that concentration, not a potency): 66.7%
Compound 3: middle estimate off by 21.3 percentage points, on the high side; the range from low to high includes it.
By their numbers in this assay, from the lowest: compound 3; then compound 2; then compound 1.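

In this assay, the chloro group on the six-membered aromatic ring, para to a large group, clearly counts: hydrogen in its place gives a number 30.6 percentage points lower from compound 1 to compound 3 (beyond the scatter), a large step for the loss of one heavy atom. For this pair, then, the position is not a silent one. Nothing measured here accounts for the size of this step. On these data alone, whether a fluoro group, a methyl group or an amine at the same place would stay close to compound 1 remains open. A single pair also cannot show whether this change would have the same effect on another core.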